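The source may report more compounds than this note shows. Statements on the series, on what has been measured and on what is new or still open speak of the compounds shown alone.

For the measured compounds named here, compound 2 `Cn1c(=O)c(S(=O)(=O)Cc2ccc(F)cc2F)cc2cnc(Nc3ccc4[nH]ccc4c3)nc21` sits at the lower end of the three numbers measured so far. In a functional assay on K562 cells (Homo sapiens) for inhibition, read by trypan blue exclusion, with a stated time of 72 h (on this read-out higher numbers stand for weaker inhibition and lower numbers for stronger inhibition), compound 2 gives 1000 nM, and compound 1 `CCCn1c(=O)c(S(=O)(=O)c2ccc(F)cc2F)cc2cnc(Nc3ccc4[nH]ccc4c3)nc21` gives 1000 nM, the same number at the digits given and thus within the scatter of each other. Going by the values given here, compound 3 `O=c1[nH]c2nc(Nc3ccc4[nH]ccc4c3)ncc2cc1S(=O)(=O)c1ccc(F)cc1F` gives 15000 nM; the only single-place step available, a 15-fold higher number from compound 1 to compound 3 (1.18 log units; beyond the scatter), concerns hydrogen in place of propyl on an aromatic nitrogen and does not touch the sulfonyl side. Compound 4 `Cc1ccc(S(=O)(=O)c2cc3cnc(Nc4ccc5[nH]ccc5c4)nc3n(C)c2=O)cc1` differs from compound 2 as follows: 4-methylphenyl in place of 2,4-difluorobenzyl on a sulfonyl sulfur. Among the compounds with values here, no measured step bears directly on this change. Compound 1 and compound 2 differ in more than one place, but their equal values suggest that exchanging the group on the sulfonyl sulfur between a benzyl and an aryl type leaves the number roughly where it was. Compound 4 is therefore expected to show a step of a 1.2-fold higher number from compound 2 to compound 4 (0.08 log units; within the scatter), within the scatter. Compound 4 is estimated at 1200 nM, with a range from 400 nM to 4000 nM.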

Compound 4, half-maximal inhibitory concentration: 750 nM
Beside the measured number, compound 4's estimate is 1.6-fold (0.20 log units) above it; the range from low to high includes it.
By their numbers in this assay, from the lowest: compounds 4, 1 and 2 (each within the scatter of the next); then compound 3.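

In this assay, for the compounds shown here, 4-methylphenyl in place of 2,4-difluorobenzyl on a sulfonyl sulfur gives a 1.3-fold lower number from compound 2 to compound 4 (0.12 log units; within the scatter), the first reading of a single change on the sulfonyl side. At this place, then, a group with 7 heavy atoms, all carbon, and a group with 9 heavy atoms, including fluorine, give numbers within the scatter of each other, although this rests on one pair alone. Nothing measured here accounts for this result.

Going by these compounds, it remains open whether the number would hold with a piperidine amine or a carboxylic acid in place of 4-methylphenyl on the sulfonyl sulfur. On these data alone, it is equally open whether 4-methylphenyl would give a similar number with hydrogen or propyl in place of the methyl on the aromatic nitrogen.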